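From methoxy to (oxetan-3-yl)oxy on compound 2

The source may report more compounds than this note shows. Statements on the series, on what has been measured and on what is new or still open speak of the compounds shown alone.

- compound 1 `CCOc1cc(-c2ccc3cc[nH]c3c2)cn2c(-c3cc(OC)c(OC)c(OC)c3)nnc12` gives 334 nM
- compound 2 `COc1cc(-c2nnc3c(OC)cc(-c4ccc5[nH]ccc5c4)cn23)cc(OC)c1OC` gives 80 nM

Within the data shown here, in a functional assay on MCF7 cells (Homo sapiens) for antiproliferative activity, read by MTT assay, with a stated time of 48 h (on this read-out higher numbers stand for weaker inhibition and lower numbers for stronger inhibition), compound 2 stands at 80 nM, the lower of the two numbers so far. Compound 1 reads 334 nM, higher by more than the usual scatter. The two differ in more than one place, so their gap does not inform the next step.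

Compound 3 `COc1cc(-c2nnc3c(OC4COC4)cc(-c4ccc5[nH]ccc5c4)cn23)cc(OC)c1OC` carries oxetan-3-yl in place of methyl on an oxygen on an aromatic ring. Among the measured compounds shown here, no measured step of this kind exists, so the expectation is cautious: a small move in this assay toward weaker inhibition, not clearly beyond the scatter. The estimate is a 1.8-fold higher number from compound 2 to compound 3 (0.24 log units; within the scatter). For compound 3 the expected value is 140 nM, with an estimated range from 45 nM to 450 nM.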

Compound 3, half-maximal inhibitory concentration: 2470 nM
For compound 3 the middle estimate is 18-fold (1.25 log units) below the measured one; measured number above the stated range.
By their numbers in this assay, from the lowest: compound 2; then compound 1; then compound 3.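

In this assay, among these compounds, the change from methoxy to (oxetan-3-yl)oxy gives a 31-fold higher number from compound 2 to compound 3 (1.49 log units; beyond the scatter), the only single-place step so far. The read-out at this position therefore depends strongly on what is carried on the oxygen: methyl goes with the lowest number of the series, and the larger oxetan-3-yl group gives up that standing. Nothing at hand accounts for the size of this step.

Among the compounds shown here, the single step does not separate the contribution of the four-membered ring from that of its ring oxygen or from the larger number of heavy atoms. A cyclobutyl group or an open 2-methoxyethyl chain on the same oxygen would bear on that question, while a free hydroxyl would show how the position reads with no carbon substituent at all.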